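Swapping the aryl group on the shared core

A few compounds are considered here, and "the series" means these few. Any claim that something is new, unique, unknown or untested is made for them only; others in the source may bear on it.

The two measured compounds share one core and differ only in the aromatic group attached to it. Compound 1 `Cc1ccc(-c2c(O)nc3cc(Cl)c([N+](=O)[O-])cc3c2OCCC2CCCCN2)c(C)c1` carries 2,4-dimethylphenyl there, and in a functional assay on cells (Pituitary gland cell) for antagonist activity at Gonadotropin-releasing hormone receptor (Rattus norvegicus) (a higher number here means a weaker inhibitor, a lower number a stronger inhibitor), compound 1 gives 400 nM. Compound 2 `O=[N+]([O-])c1cc2c(OCCC3CCCCN3)c(-c3cccs3)c(O)nc2cc1Cl` carries thiophen-2-yl instead, and in this assay compound 2 gives 220 nM. The step of a 1.8-fold lower number from compound 1 to compound 2 (0.26 log units; within the scatter) is small, so compound 2 has the lower of the two numbers but stands within the scatter of compound 1.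

Compound 3 `O=[N+]([O-])c1cccc(-c2c(O)nc3cc(Cl)c([N+](=O)[O-])cc3c2OCCC2CCCCN2)c1` changes the same position once more: 3-nitrophenyl in place of thiophen-2-yl on an aromatic carbon. Among the compounds with values here, the only measured step that touches this position is the one from compound 1 to compound 2, and that step stayed within the scatter. Nothing measured here shows that the identity of this aryl group moves the number much, so the expectation for compound 3 is a step of a 1.4-fold higher number from compound 2 to compound 3 (0.13 log units; within the scatter) that does not exceed the scatter. Compound 3 is therefore estimated at 300 nM in this assay, with a range from 100 nM to 900 nM.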

Compound 3, half-maximal inhibitory concentration: 100 nM
Estimate against measurement, compound 3: 3.0-fold (0.48 log units) above; measured number inside the range.
By their numbers in this assay, from the lowest: compound 3; then compounds 2 and 1 (each within the scatter of the next).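

In this assay, 3-nitrophenyl in place of thiophen-2-yl gives a 2.2-fold lower number from compound 2 to compound 3 (0.34 log units; beyond the scatter) and 3-nitrophenyl in place of 2,4-dimethylphenyl gives a 4.0-fold lower number from compound 1 to compound 3 (0.60 log units; beyond the scatter) on the same aromatic carbon of the shared core. The earlier pair stayed within the scatter and so could not show that this position responds to the choice of aromatic group, whereas these two modest steps show that it does, with compound 3 set apart from both compound 1 and compound 2. Nothing available here explains why 3-nitrophenyl gives the lower number, so the result stands as an observation about these three compounds only.

The three compounds cannot separate the nitro group from the phenyl ring that carries it, and a plain phenyl group, or a phenyl ring with an amine or a carboxylic acid in place of the nitro group, would address that question. On these data alone, all three also keep the same 2-(piperidin-2-yl)ethoxy group, so it remains open whether 3-nitrophenyl would give a similar step alongside a different chain there, such as a longer one.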